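This account rests on a few compounds, and the source may have more. Where it says the series, first, only, none or still open, it means among the compounds named here.

Measured so far in an assay on isolated protein for inhibition of acid ceramidase (Homo sapiens), read by LC-MS, with a stated time of 1 h; on this read-out higher numbers stand for weaker inhibition and lower numbers for stronger inhibition:
compound 1 `O=C(NCCCCc1ccccc1)n1cc(-c2ccccc2)oc1=O`: 90 nM
compound 2 `COc1cccc(-c2cn(C(=O)NCCCCc3ccccc3)c(=O)o2)c1`: 341 nM
compound 3 `O=C(NCCCCc1ccccc1)n1cc(-c2cccnc2)oc1=O`: 70 nM

Compound 3 gives the lowest number of the three, but the step of a 1.3-fold lower number from compound 1 to compound 3 (0.11 log units; within the scatter) lies within the scatter, so compounds 1 and 3 cannot be ordered; only compound 2 stands clearly apart, a 4.9-fold lower number from compound 2 to compound 3 (0.69 log units; beyond the scatter).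

Compound 4 `O=C(NCCCCc1ccccc1)n1cc(-c2cnccn2)oc1=O` differs from compound 3 by pyrazin-2-yl in place of pyridin-3-yl on an aromatic carbon. Among the measured compounds shown here, the one measured step that swaps the aromatic substituent without adding a group, a 1.3-fold lower number from compound 1 to compound 3 (0.11 log units; within the scatter), stayed within the scatter; the steps involving the methoxy group, a 3.8-fold higher number from compound 1 to compound 2 (0.58 log units; beyond the scatter) and a 4.9-fold lower number from compound 2 to compound 3 (0.69 log units; beyond the scatter), concern a different kind of change and bear little on this one. No second ring nitrogen has been tested. The expected step is therefore small, a 1.4-fold higher number from compound 3 to compound 4 (0.15 log units; within the scatter), with no direction beyond the scatter. For compound 4 the estimate is 100 nM, range 40 nM to 260 nM.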

Compound 4, half-maximal inhibitory concentration: 32 nM
Compound 4: the middle estimate sits 3.1-fold (0.49 log units) above what was measured; the whole stated range lies above it.
By their numbers in this assay, from the lowest: compound 4; then compounds 3 and 1 (each within the scatter of the next); then compound 2.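

In this assay, the aromatic carbon next to the ring oxygen tolerates a second ring nitrogen and responds to it: pyrazin-2-yl in place of pyridin-3-yl gives a 2.2-fold lower number from compound 3 to compound 4 (0.34 log units; beyond the scatter). The same group gives a 2.8-fold lower number from compound 1 to compound 4 (0.45 log units; beyond the scatter) against phenyl and an 11-fold lower number from compound 2 to compound 4 (1.03 log units; beyond the scatter) against 3-methoxyphenyl, so compound 4 holds the lowest number of the four, whereas pyridin-3-yl alone could not be separated from phenyl. No measurement here explains this step.

Open, going by these compounds, is whether the count of ring nitrogens or their arrangement matters, which a pyrimidin-5-yl group would address. Also open, on these data alone, is whether an amine on the pyrazine ring would be tolerated.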